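A few compounds are considered here, and "the series" means these few. Any claim that something is new, unique, unknown or untested is made for them only; others in the source may bear on it.

Compound 1 `CC1(C)C=C(n2ccccc2=O)c2ccccc2O1` is the parent of this small set. In a functional assay (trachea) with Rattus norvegicus as the target (on this read-out lower numbers stand for lower potency and higher numbers for higher potency (the scale is a negative logarithm)), compound 1 gives 5.05, the lowest of the three measured numbers. Compound 2 `COc1ccc2c(c1)C(n1ccccc1=O)=CC(C)(C)O2` carries a methoxy group on an aromatic carbon and gives 5.99, while compound 3 `CCC(=O)c1ccc2c(c1)C(n1ccccc1=O)=CC(C)(C)O2` carries a propanoyl group at that position and gives 5.85. The two substitutions move the read-out in the same direction: a number 0.94 log units higher from compound 1 to compound 2 (beyond the scatter) and a number 0.80 log units higher from compound 1 to compound 3 (beyond the scatter), and between the two substituted compounds there is a number 0.14 log units lower from compound 2 to compound 3 (within the scatter).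

Compound 4 `CC1(C)C=C(n2ccccc2=O)c2cc(C(=O)c3ccco3)ccc2O1` is not yet measured. It differs from compound 1 by (furan-2-yl)carbonyl in place of hydrogen on an aromatic carbon. Among the compounds with values here, the nearest measured step is the one from compound 1 to compound 3, since a propanoyl group and a (furan-2-yl)carbonyl group both enter the same aromatic carbon as a carbonyl-bearing substituent. On that basis a gain of similar size is expected for compound 4, namely a number 0.80 log units higher from compound 1 to compound 4 (beyond the scatter). The estimate for compound 4 in this assay is therefore 5.85, within a range from 5.35 to 6.35.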

Compound 4, logarithm of the reciprocal of the active concentration, log(1/C): 5.92
Compound 4: the middle estimate sits 0.07 log units below what was measured; the range from low to high includes it.
By their numbers in this assay, from the lowest: compound 1; then compounds 3, 4 and 2 (each within the scatter of the next).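

In this assay, the gain over the unsubstituted parent also holds for a substituent that brings a five-membered aromatic ring to this aromatic carbon (a number 0.87 log units higher from compound 1 to compound 4 (beyond the scatter)). Putting furan-2-yl in place of ethyl on the carbonyl carbon gives no difference that can be read (a number 0.07 log units higher from compound 3 to compound 4 (within the scatter)), and the same is true of (furan-2-yl)carbonyl in place of methoxy (a number 0.07 log units lower from compound 2 to compound 4 (within the scatter)). Methoxy, propanoyl and (furan-2-yl)carbonyl therefore cannot be told apart here, although all three stand clearly apart from hydrogen, and nothing measured alongside these numbers explains this.

The compounds shown leave open whether an amine or a carboxylic acid on this carbon would give a similar number. They also leave open how a longer chain or a phenyl group on the carbonyl carbon would read.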